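Carbonyl substituent change from compound 1 to compound 3

A few compounds are considered here, and "the series" means these few. Any claim that something is new, unique, unknown or untested is made for them only; others in the source may bear on it.

- compound 1 `CCNC(=O)c1noc(-c2cc(C(C)C)c(O)cc2O)c1NC(=O)[C@@H]1CC[C@H](C(=O)OC)C1` gives 40 nM
- compound 2 `CCNC(=O)c1noc(-c2cc(C(C)C)c(O)cc2O)c1NC(=O)[C@H]1CC[C@H](CNS(=O)(=O)c2ccc(F)cc2)CC1` gives 888 nM
- compound 3 `CCNC(=O)c1noc(-c2cc(C(C)C)c(O)cc2O)c1NC(=O)c1cc(CC)on1` is not yet measured

In an ADME assay on L6 cells (Rattus norvegicus) for cytotoxicity (on this read-out lower numbers stand for stronger inhibition and higher numbers for weaker inhibition), compound 1 gives 40 nM as the lower of the two numbers, and the gap to compound 2 lies beyond the scatter. Going to compound 3 places 5-ethyl-1,2-oxazol-3-yl in place of 3-(methoxycarbonyl)cyclopentyl on a carbonyl carbon. For the measured compounds named here, no measured step covers this change, and the two values give only a rough spread. Since compound 1 at 40 nM sits at the low end, a rise towards weaker inhibition is expected. The estimated change is a 3.8-fold higher number from compound 1 to compound 3 (0.57 log units; beyond the scatter) as a moderate step beyond the scatter. Compound 3 is expected at 150 nM with a range of 35 nM to 650 nM as estimated.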

Compound 3, half-maximal inhibitory concentration: 20 nM
Compound 3: the middle estimate sits 7.5-fold (0.88 log units) above what was measured, outside the stated range (below it).
By their numbers in this assay, from the lowest: compounds 3 and 1 (each within the scatter of the next); then compound 2.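

In this assay, 5-ethyl-1,2-oxazol-3-yl in place of 3-(methoxycarbonyl)cyclopentyl on a carbonyl carbon gives a 2.0-fold lower number from compound 1 to compound 3 (0.30 log units; within the scatter) and so leaves the two groups unseparated on this read-out. This position therefore accepts a five-membered aromatic ring with 2 hetero atoms as well as a five-membered non-aromatic ring of carbon only, and the methoxycarbonyl group and both defined stereocentres can go without a step beyond the scatter. No supporting data bear on the reason for this result.

Still open, going by these compounds, is how a carboxylic acid or a primary amine on the ring would read at this position. On these data alone, a propyl chain in place of the ethyl of 5-ethyl-1,2-oxazol-3-yl is equally open.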